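Swapping the amino chain of compound 2

The source may hold more compounds than are shown below. What is called first, only, known or untested is meant among the compounds shown, and "the series" means these compounds.

Compound 1 `CC(C)c1c(-c2nnc(NCCO)o2)cn2ncnc(Nc3cc(C(=O)NC4CC4)c(F)cc3F)c12` gives 140 nM
Compound 2 `CC(C)c1c(-c2nnc(NCC(C)(C)CN)o2)cn2ncnc(Nc3cc(C(=O)NC4CC4)c(F)cc3F)c12` gives "not determined" (no result reported)

In a functional assay on HUVEC cells (Homo sapiens) for antiproliferative activity (a lower number here means a stronger inhibitor, a higher number a weaker inhibitor), compound 1 gives 140 nM as its half-maximal inhibitory concentration. Compound 2 stands at "not determined" (no result reported) in the same test, so it offers no number to start from. Compound 3 `CNCCCNc1nnc(-c2cn3ncnc(Nc4cc(C(=O)NC5CC5)c(F)cc4F)c3c2C(C)C)o1` has yet to be measured. Its difference from compound 2 is 2-(methylamino)ethyl in place of 1-(aminomethyl)-1-methylethyl on a saturated chain carbon bound to a nitrogen on an aromatic ring, with 3-(methylamino)propyl taking the place of 2-(aminomethyl)-2-methylpropyl. Within the data shown here, no measured step speaks to this change, so no step beyond the usual scatter is expected in this assay, in either direction. Among the measured compounds shown here, with no figure for compound 2, the only anchor is compound 1 at 140 nM, and the range has to stay wide. Compound 3 is estimated at 110 nM (expected range 35 nM to 350 nM).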

Compound 3, half-maximal inhibitory concentration: 62 nM
For compound 3 the middle estimate is 1.8-fold (0.25 log units) above the measured one; measured number inside the range.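

In this assay, putting (methylamino)methyl in place of hydroxy on a saturated chain carbon, two bonds along the chain from a nitrogen on an aromatic ring, gives a 2.3-fold lower number from compound 1 to compound 3 (0.35 log units; beyond the scatter). This shows that the 3-(methylamino)propyl chain at this place gives a stronger inhibitor than the hydroxy-bearing chain of compound 1, while the step from compound 2 to compound 3 cannot be read, as compound 2 has no number. Nothing at hand bears on what lies behind this step.

The compounds shown leave open whether the step comes with the nitrogen itself or with the length of the chain, which a plain propyl chain or a hydroxypropyl chain would separate. From the compounds shown here alone, how a dimethylamine, a primary amine or a longer chain would fare at this place also remains open.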